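A few compounds are considered here, and "the series" means these few. Any claim that something is new, unique, unknown or untested is made for them only; others in the source may bear on it.

Series notes. Compound 1 `CC(=O)Nc1ccc(S(=O)(=O)Nc2cccc(-c3nc(-c4ccc(NC(=O)c5cccnc5)cc4Cl)no3)c2)cc1`, compound 2 `CCNC(=O)Nc1ccc(S(=O)(=O)Nc2cccc(-c3nc(-c4ccc(NC(=O)c5cccnc5)cc4Cl)no3)c2)cc1` and compound 3 `CCN(CC)C(=O)Nc1ccc(S(=O)(=O)Nc2cccc(-c3nc(-c4ccc(NC(=O)c5cccnc5)cc4Cl)no3)c2)cc1` share one core and differ only at a carbonyl carbon. In a functional assay on MDA-MB-231 cells (Homo sapiens) for antiproliferative activity, read by MTT assay, with a stated time of 72 h (a higher number here means a weaker inhibitor, a lower number a stronger inhibitor), compound 1 gives 2500 nM, compound 2 gives 3100 nM and compound 3 gives 8700 nM, the highest number of the three: a 3.5-fold higher number from compound 1 to compound 3 (0.54 log units; beyond the scatter) and a 2.8-fold higher number from compound 2 to compound 3 (0.45 log units; beyond the scatter) both lie beyond the scatter, whereas a 1.2-fold higher number from compound 1 to compound 2 (0.09 log units; within the scatter) does not. Compound 4 `O=C(Nc1ccc(-c2noc(-c3cccc(NS(=O)(=O)c4ccc(NC(=O)N5CCOCC5)cc4)c3)n2)c(Cl)c1)c1cccnc1` is the next member: morpholin-4-yl in place of diethylamino on a carbonyl carbon. Both measured steps onto compound 3 raised the number modestly, and compound 4, like compound 3, carries a nitrogen without hydrogen on that carbonyl carbon, so in this assay only a step within the scatter is expected, a 1.2-fold lower number from compound 3 to compound 4 (0.06 log units; within the scatter). Compound 4 is estimated at 7500 nM, with a range of 3000 nM to 20000 nM.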

Compound 4, half-maximal inhibitory concentration: > 10000 nM
Compound 4 was reported as a limit (the forecaster's own chance of this, stated with the estimate: 10%); middle value at least 1.3-fold (0.12 log units) from the limit.
By their numbers in this assay, from the lowest: compounds 1 and 2 (each within the scatter of the next); then compound 3. At a limit, above all of these: compound 4.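

Compound 4 is reported only as a limit, not a number: the limit of > 10000 nM in this assay, at which 1 of the 4 values shown sits. Against diethylamino, morpholin-4-yl on this carbonyl carbon gives an at least 1.1-fold higher number from compound 3 to compound 4 (0.06 log units; that floor lies within the scatter), so the new ring with its oxygen brings no lowering of the number, while the true size of this step stays unread. Against the other two groups the step is clearer, with ethylamino replaced in an at least 3.2-fold higher number from compound 2 to compound 4 (0.50 log units; beyond the scatter) and methyl replaced in an at least 4.0-fold higher number from compound 1 to compound 4 (0.60 log units; beyond the scatter).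

On these data alone, how far compound 4 lies past its limit remains open. Also open, as far as these compounds go, is whether piperidin-1-yl or piperazin-1-yl on this carbonyl carbon would behave like morpholin-4-yl.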